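Chloro for bromo: expectation for compound 4

The compounds below may be only part of what the source reports. "The series", "measured", "known", "first", "only" and "open" are said of these compounds alone.

Measured so far in a physicochemical assay for lipophilicity, measured as octanol-water partition; on this read-out lower numbers stand for lower lipophilicity and higher numbers for higher lipophilicity:
compound 1 `CCN1C(=O)c2c(nc(C(N)=O)n2Cc2ccc(O)c(Br)c2)N2C1=N[C@@H]1CCC[C@@H]12` gives 3.03
compound 2 `CCN1C(=O)c2c(nc(C(N)=O)n2Cc2ccc(O)c(Cl)c2)N2C1=N[C@@H]1CCC[C@@H]12` gives 2.76
compound 3 `CCN1C(=O)c2c(nc(OC)n2Cc2ccc(OC)c(Br)c2)N2C1=N[C@@H]1CCC[C@@H]12` gives 4.59

Compound 4 `CCN1C(=O)c2c(nc(OC)n2Cc2ccc(OC)c(Cl)c2)N2C1=N[C@@H]1CCC[C@@H]12` is not yet measured. It differs from compound 3 in one place: chloro in place of bromo on an aromatic carbon The same kind of change separates compound 1 from compound 2: chloro in place of bromo on an aromatic carbon The surroundings are not identical, though: in compound 3 the carbon that changes is ortho to a methoxy group, in compound 1 ortho to a hydroxy group, so the two changes are of the same kind, not the same. How the core of compound 3 differs from the core of compound 1 is not broken down here. Within the data shown here, the one measured step in this assay is a number 0.27 log units lower from compound 1 to compound 2 (within the scatter), and compound 3 stands highest of the three. Compound 4 is therefore expected near 4.32, between 4 and 4.65, an expected step of a number 0.27 log units lower from compound 3 to compound 4 (within the scatter), resting on the small step of a number 0.27 log units lower from compound 1 to compound 2 (within the scatter) seen for compound 1 and compound 2 with the same kind of change.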

Compound 4, partition coefficient: 4.32
Compound 4: the middle estimate sits on the measured number at the digits printed; measured number inside the range.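

In this assay, chloro in place of bromo on an aromatic carbon gives a number 0.27 log units lower from compound 3 to compound 4 (within the scatter), matching at the digits printed a number 0.27 log units lower from compound 1 to compound 2 (within the scatter) on the core of compound 1. Among these compounds, the change therefore carries between these two cores, with a methoxy or a hydroxy group ortho to the changing carbon, but both steps lie within the scatter, so the pair shows only that the swap leaves no step beyond it, not that chloro and bromo differ on this read-out. Two cores are no rule for the series, and nothing here bears on why the step has this size.

From the compounds shown here alone, whether the same holds with a fluoro or trifluoromethyl group in place of the halogen stays open. So does the outcome on a core carrying an amine or a carboxylic acid.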